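The source may hold more compounds than are shown below. What is called first, only, known or untested is meant among the compounds shown, and "the series" means these compounds.

Notes on the series. Compound 1 `Cc1nn(-c2ncnc3nc[nH]c23)c2c1C(OCC(=O)c1ccc(F)cc1)CC(=O)N2` gives 3 nM in a functional assay on HEK293 cells for agonist activity at G-protein coupled receptor 39 (Homo sapiens), read by scintillation proximity assay and inositol phosphate accumulation, with a stated time of 75 min, in the presence of a further agent that is not named here; a lower number here means that less compound is needed, a higher number that more compound is needed for the effect. Compound 2 `Cc1nn(-c2ncnc3nc[nH]c23)c2c1C(OCc1ccccc1C#N)CC(=O)N2` gives 8 nM, and compound 3 `COc1ccc(CCOC2CC(=O)Nc3c2c(C)nn3-c2ncnc3nc[nH]c23)cc1` gives 2 nM. Compound 2 stands highest of the three numbers: there is a 2.7-fold higher number from compound 1 to compound 2 (0.43 log units; beyond the scatter) and a 4.0-fold lower number from compound 2 to compound 3 (0.60 log units; beyond the scatter), while between compound 1 and compound 3 the step is a 1.5-fold lower number from compound 1 to compound 3 (0.18 log units; within the scatter). Compound 4 `Cc1nn(-c2ncnc3nc[nH]c23)c2c1C(c1ccc(F)cc1Cl)CC(=O)N2` differs from compound 2 by 2-chloro-4-fluorophenyl in place of (2-cyanobenzyl)oxy on a saturated ring carbon. The measured steps each exchange one group on the saturated chain carbon bound to an oxygen and keep that oxygen; none removes it, so they bear on compound 4 only loosely, and their modest size suggests at most a modest move in this assay, direction uncertain. Compound 4 is expected at 10 nM, within a range of 2 nM to 60 nM, which would mean a 1.3-fold higher number from compound 2 to compound 4 (0.10 log units; within the scatter).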

Compound 4, half-maximal effective concentration: 9 nM
Compound 4: the middle estimate sits 1.1-fold (0.05 log units) above what was measured; the measured number falls inside the stated range.
By their numbers in this assay, from the lowest: compounds 3 and 1 (each within the scatter of the next); then compounds 2 and 4 (each within the scatter of the next).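

Working in this assay, the earlier steps all exchanged groups beyond the oxygen, while this change removes the whole (2-cyanobenzyl)oxy, oxygen included, and puts 2-chloro-4-fluorophenyl on the saturated ring carbon, giving a 1.1-fold higher number from compound 2 to compound 4 (0.05 log units; within the scatter) with no change beyond the scatter. For this pair, the position therefore accepts an aromatic ring without the oxygen or the chain. No measurement at hand explains this result.

From the compounds shown here alone, it remains open whether an unsubstituted phenyl would hold the number without the chlorine and fluorine. Also open, going by these compounds, is how an amine or a carboxylic acid on this ring carbon would read.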